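A few compounds are considered here, and "the series" means these few. Any claim that something is new, unique, unknown or untested is made for them only; others in the source may bear on it.

The measured compounds:

Compound 1 `CN(C)CCCOc1c(OCc2ccccc2)cc(O)c2c(=O)cc(-c3ccccc3)oc12` gives 3210 nM in a functional assay on MCF7 cells (Homo sapiens) for cytotoxicity, read by MTT assay, with a stated time of 72 h; on this read-out higher numbers stand for weaker inhibition and lower numbers for stronger inhibition.
Compound 2 `O=c1cc(-c2ccccc2)oc2c(OCCCN3CCCC3)c(OCc3ccccc3)cc(O)c12` gives 2230 nM in this assay.
Compound 3 `CN1CCN(CCCOc2c(OCc3ccccc3)cc(O)c3c(=O)cc(-c4ccccc4)oc23)CC1` gives 1020 nM in this assay.

Compound 3 has the lowest number of the three. Its nearest neighbour is compound 2, with a 2.2-fold lower number from compound 2 to compound 3 (0.34 log units; beyond the scatter), and its furthest is compound 1, with a 3.1-fold lower number from compound 1 to compound 3 (0.50 log units; beyond the scatter); both of these steps lie beyond the scatter, so compound 3 stands alone at the strong end on these numbers. Compound 1 and compound 2 sit close together, with a 1.4-fold lower number from compound 1 to compound 2 (0.16 log units; within the scatter), a step within the scatter.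

Compound 4 `CN(C)CCCCOc1c(OCc2ccccc2)cc(O)c2c(=O)cc(-c3ccccc3)oc12` is not yet measured. It differs from compound 3 in one place: (dimethylamino)methyl in place of 4-methylpiperazin-1-yl on a saturated chain carbon, three bonds along the chain from an oxygen on an aromatic ring. The change therefore brings back the dimethylamino group seen in compound 1, while the chain that carries it is one carbon longer than in compound 1. Among the compounds with values here, the step that bears most directly on this is the one from compound 1 to compound 3, where replacing dimethylamino by 4-methylpiperazin-1-yl gave a 3.1-fold lower number from compound 1 to compound 3 (0.50 log units; beyond the scatter). Reversing that change is expected to raise the number by a similar modest amount; the added chain length has no precedent among the measured compounds, so it widens the range but does not set its direction. Compound 4 is therefore expected to give about 3000 nM in this assay, within 1400 nM to 6500 nM, which means an expected step of a 2.9-fold higher number from compound 3 to compound 4 (0.47 log units; beyond the scatter).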

Compound 4, half-maximal inhibitory concentration: 3210 nM
Estimate against measurement, compound 4: 1.1-fold (0.03 log units) below; low and high end bracket the measured number.
By their numbers in this assay, from the lowest: compound 3; then compounds 2, 1 and 4 (each within the scatter of the next).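

Exchanging the 3-(4-methylpiperazin-1-yl)propyl chain for 4-(dimethylamino)butyl gives a 3.1-fold higher number from compound 3 to compound 4 (0.50 log units; beyond the scatter) in this assay, so among these compounds the 4-methylpiperazin-1-yl group alone stands apart at the strong end. Lengthening the chain that carries dimethylamino gives no change at the digits printed from compound 1 to compound 4 (within the scatter), and the change from the pyrrolidin-1-yl side chain gives a 1.4-fold higher number from compound 2 to compound 4 (0.16 log units; within the scatter), so this first variation in chain length, seen with dimethylamino only, leaves the number within the scatter. No measurement here accounts for the standing of the 4-methylpiperazin-1-yl group or for the lack of a chain-length effect.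

Going by these compounds, whether a longer chain would also leave the number unchanged with pyrrolidin-1-yl or 4-methylpiperazin-1-yl remains open, since the dimethylamino pair is the only one here that varies the chain. Also open, on these data alone, is how a morpholine, a piperidine, a primary amine or a shorter 2-(dimethylamino)ethyl chain would read at this place on the shared core.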